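This account rests on a few compounds, and the source may have more. Where it says the series, first, only, none or still open, it means among the compounds named here.

Measured so far:
- compound 1 `Cc1c(Cl)cccc1C(=O)NC(CCN(C)C)c1ccc(Cl)cc1`: 1740 nM
- compound 2 `CN(C)CCC(NC(=O)c1ccc(Oc2ccccc2)cc1)c1ccc(Cl)cc1`: 66.1 nM

In an assay on NIH3T3 cells with Urotensin-2 receptor (Homo sapiens) as the target (on this read-out lower numbers stand for an effect already at smaller amounts and higher numbers for an effect only at larger amounts of compound), compound 2 gives the lowest of the two numbers; the nearest is compound 1, whose number is higher by a margin beyond the scatter. Compound 3 `CN(C)CCC(NC(=O)c1ccccc1)c1ccc(Cl)cc1` is the next step from compound 2: hydrogen in place of phenoxy on an aromatic carbon, on an aromatic carbon of a six-membered aromatic ring of carbon only, para to a large group. Among the compounds with values here, no step of this kind has been measured in this assay, so the expected size rests on the structural change alone. The loss of the phenoxy group is expected to cost potency, with a step of an 11-fold higher number from compound 2 to compound 3 (1.02 log units; beyond the scatter) beyond the scatter. Compound 3 is estimated at 700 nM, within 150 nM to 3000 nM.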

Compound 3, half-maximal effective concentration: 1410 nM
The estimate for compound 3 lay 2.0-fold (0.30 log units) below the measured number, and the stated range covers the measured number.
By their numbers in this assay, from the lowest: compound 2; then compounds 3 and 1 (each within the scatter of the next).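

In this assay, the phenoxy group on this aromatic carbon matters strongly: hydrogen in its place gives a 21-fold higher number from compound 2 to compound 3 (1.33 log units; beyond the scatter). Chloro and methyl substitution on the ring offers no comparable change, since phenyl in place of 3-chloro-2-methylphenyl gives a 1.2-fold lower number from compound 1 to compound 3 (0.09 log units; within the scatter), so only phenoxy separates itself here. No supporting data explain the size of the phenoxy step.

As far as these compounds go, it remains open whether the oxygen link or the second ring matters more. A methoxy group or a directly attached phenyl at the same carbon would separate the two.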